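The source may hold more compounds than are shown below. What is called first, only, known or untested is meant among the compounds shown, and "the series" means these compounds.

Working notes on the series built on the shared core of compound 1 `CN(C(=O)c1ccccc1)c1ccc(C(O)(C(F)(F)F)C(F)(F)F)cc1`. In an ADME assay on Li23 cells (Homo sapiens) for cytotoxicity, read by WST assay (on this read-out higher numbers stand for lower toxicity in this test and lower numbers for higher toxicity in this test), compound 1 gives 65000 nM. Compound 2 `CCCC(=O)N(C)c1ccc(C(O)(C(F)(F)F)C(F)(F)F)cc1` reaches only a limit of the method, > 100000 nM. Compound 3 `CN(C(=O)c1ccccn1)c1ccc(C(O)(C(F)(F)F)C(F)(F)F)cc1` likewise returns only a limit, > 100000 nM. The measured steps read an at least 1.5-fold higher number from compound 1 to compound 2 (0.18 log units; that floor lies within the scatter) and an at least 1.5-fold higher number from compound 1 to compound 3 (0.18 log units; that floor lies within the scatter), while a step that the two limits leave unreadable from compound 2 to compound 3. Both limits rest at the limit of > 100000 nM in this assay, at which 2 of the 3 values shown sit. Compound 4 `CN(C(=O)c1cccnc1)c1ccc(C(O)(C(F)(F)F)C(F)(F)F)cc1` differs from compound 3 by pyridin-3-yl in place of pyridin-2-yl on a carbonyl carbon. Within the data shown here, no measured step covers this exchange directly; the two steps from compound 1 are floors lying within the scatter, so no shift beyond the scatter is expected in this assay. Compound 4 is therefore estimated at 100000 nM, in a range from 45000 nM to 250000 nM. The step of a number no higher from compound 3 to compound 4 (the limit leaves the size open) is the expectation.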

Compound 4, half-maximal cytotoxic concentration: 63000 nM
The estimate for compound 4 lay 1.6-fold (0.20 log units) above the measured number; low and high end bracket the measured number.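

In this assay, swapping pyridin-2-yl for pyridin-3-yl on a carbonyl carbon, with the same atoms joined differently, gives an at least 1.5-fold lower number from compound 3 to compound 4 (0.20 log units; that floor lies within the scatter), and replacing propyl gives an at least 1.5-fold lower number from compound 2 to compound 4 (0.20 log units; that floor lies within the scatter); both are only floors, because the starting values are limits: the limit of > 100000 nM in this assay, at which 2 of the 4 values shown sit. Pyridin-3-yl reads level with phenyl, a 1.0-fold lower number from compound 1 to compound 4 (0.01 log units; within the scatter), so a ring nitrogen in this group does not by itself hold the read-out at the limit.

As far as these compounds go, the true size of both floors stays open. From the compounds shown here alone, whether a longer chain such as butyl, or a carboxylic acid on the ring, follows compound 2 or compound 4 also stays open.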